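Tolerability in Liver Cells: From Compound 3 to Compound 4

A few compounds are considered here, and "the series" means these few. Any claim that something is new, unique, unknown or untested is made for them only; others in the source may bear on it.

Compound 1 `CN(c1nc(=O)c2cc(C(F)(F)F)cc([N+](=O)[O-])c2s1)[C@H]1CCN(Cc2ccccc2)C1` gives > 10000 nM in an ADME assay on HepG2 cells (Homo sapiens) for cytotoxicity, read by MTT assay, with a stated time of 24 h (a lower number here means that less compound is tolerated, a higher number that more compound is tolerated), and this value is a limit.
Compound 2 `O=c1nc(N2CCC(F)(F)CC2)sc2c([N+](=O)[O-])cc(C(F)(F)F)cc12` gives > 10000 nM in this assay, again a limit.
Compound 3 `Cc1ccc(CNc2nc(=O)c3cc(C(F)(F)F)cc([N+](=O)[O-])c3s2)n1C` gives > 10000 nM in this assay, likewise a limit.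

Compound 3 therefore stands where every measured compound stands: at the limit, since (the limit of > 10000 nM in this assay, at which 3 of the 3 values shown sit). Among the measured compounds shown here, the one measured step, a step that the two limits leave unreadable from compound 2 to compound 3, is left unreadable by the two limits. Compound 4 `O=c1nc(NCc2ccc3c(c2)OCCO3)sc2c([N+](=O)[O-])cc(C(F)(F)F)cc12` differs from compound 3 by 2,3-dihydro-1,4-benzodioxin-6-yl in place of 1,5-dimethyl-1H-pyrrol-2-yl on a saturated chain carbon bound to a nitrogen on an aromatic ring. For the measured compounds named here, no measured step reads on this change, so no step beyond the scatter is expected, and compound 4 is expected to sit at the limit as well. The estimate for compound 4 is 20000 nM, with a range from 8000 nM to 50000 nM. This estimate means an expected step that the limit leaves unreadable from compound 3 to compound 4.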

Compound 4, half-maximal cytotoxic concentration: > 10000 nM
Compound 4 gave a limit, no number (the forecaster's own chance of this, stated with the estimate: 80%); the middle value is on the limit's open side.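

Compound 3 and compound 4 are both limits, so no step can be read between them. The compounds shown leave open how any of these structural changes affects tolerability in this assay, with every value at one limit: the limit of > 10000 nM in this assay, at which 4 of the 4 values shown sit.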